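The source may hold more compounds than are shown below. What is called first, only, known or untested is meant among the compounds shown, and "the series" means these compounds.

Measured so far in a functional assay on HeLa cells (Homo sapiens) for inhibition, with a stated time of 72 h; on this read-out lower numbers stand for an effect already at smaller amounts and higher numbers for an effect only at larger amounts of compound:

Compound 1, `CCOc1cc(CNCc2ccncc2)ccc1OCc1ccc(Cl)cc1`: 2500 nM
Compound 2, `COc1cc(OCc2cnc(Cl)c(Cl)c2)ccc1CNCc1ccncc1`: 400 nM
Compound 3, `COc1cc(CNCc2ccccn2)ccc1OCc1cccc(Cl)c1`: 18000 nM

Among these three numbers compound 1 stands second highest. Its nearest neighbour is compound 2, whose lower number lies beyond the scatter, and furthest from it is compound 3, whose higher number also lies beyond the scatter. No two of these compounds differ in just one place, so no single change has yet been followed on its own.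

The untested compound 4, `Clc1ccc(COc2ccc(CNCc3ccncc3)cc2)cc1`, differs from compound 1 in one place: hydrogen in place of ethoxy on an aromatic carbon. In other words, the ethoxy group is simply removed and the shared core otherwise stays as it is. Among the compounds with values here, nothing among the measured compounds shows what this removal does by itself; compounds 2 and 3 both carry a methoxy in place of the ethoxy while also differing elsewhere. A moderate change, most likely towards a higher number, is therefore expected for compound 4 in this assay, yet it could also stay within the scatter.

Compound 4 is thus estimated at 5000 nM, with a range from 1500 nM to 15000 nM, which would mean an expected step of a 2.0-fold higher number from compound 1 to compound 4 (0.30 log units; within the scatter).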

Compound 4, half-maximal effective concentration: 4000 nM
Compound 4: middle estimate off by 1.3-fold (0.10 log units), on the high side; the measured number falls inside the stated range.
By their numbers in this assay, from the lowest: compound 2; then compounds 1 and 4 (each within the scatter of the next); then compound 3.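

In this assay, taking the ethoxy group off the aromatic carbon gives a 1.6-fold higher number from compound 1 to compound 4 (0.20 log units; within the scatter) and so this first direct test of the position shows no change that can be told apart from the usual spread of repeated measurements. An effect in this range therefore does not depend on having ethoxy at this place, ortho to the (4-chlorobenzyl)oxy group. Nothing available gives a reason for this outcome.

What the compounds shown leave open is whether methoxy alone at this place would behave like ethoxy or hydrogen, since compounds 2 and 3 each differ in other places as well. Also open, going by these compounds, is whether a longer chain such as butoxy, or an amine or a carboxylic acid here, would shift the number beyond the scatter.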